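The source may hold more compounds than are shown below. What is called first, only, known or untested is meant among the compounds shown, and "the series" means these compounds.

The measured compounds:
Compound 1 `O=C(Nc1cccc(-c2oc3cc(-c4ccc(F)cc4)ccc3c(=O)c2O)c1)c1ccccc1F` gives 5630 nM in a functional assay on HeLa cells (Homo sapiens) for antiproliferative activity, read by CCK-8 assay, with a stated time of 72 h; on this read-out higher numbers stand for weaker inhibition and lower numbers for stronger inhibition.
Compound 2 `O=C(Nc1cccc(-c2oc3cc(-c4ccc(F)cc4)ccc3c(=O)c2O)c1)c1ccc(Cl)cc1` gives 3670 nM in this assay.

Among the measured compounds shown here, compound 2 stands at one of only two numbers so far, and the single step between them, a 1.5-fold lower number from compound 1 to compound 2 (0.19 log units; within the scatter), lies within the scatter, so the two compounds cannot be told apart on this read-out. Compound 3 `CCc1ccc(C(=O)Nc2cccc(-c3oc4cc(-c5ccc(F)cc5)ccc4c(=O)c3O)c2)cc1` differs from compound 2 on the 4-chlorophenyl group attached to the carbonyl: ethyl in place of chloro on an aromatic carbon. For the measured compounds named here, no measured step tests an ethyl group, and the one step known concerned a different replacement and stayed small. Nothing in the data points to a direction, so for compound 3 the expected step is a 1.0-fold lower number from compound 2 to compound 3 (0.02 log units; within the scatter), no more than the scatter. Compound 3 is expected to give about 3500 nM in this assay, with a likely range from 1500 nM to 8500 nM.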

Compound 3, half-maximal inhibitory concentration: 21000 nM
Estimate against measurement, compound 3: 6.0-fold (0.78 log units) below, outside the stated range (above it).
By their numbers in this assay, from the lowest: compounds 2 and 1 (each within the scatter of the next); then compound 3.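

The position on the ring attached to the carbonyl is not indifferent to what it carries in this assay: ethyl in place of chloro, a change from one heavy atom to two, gives a 5.7-fold higher number from compound 2 to compound 3 (0.76 log units; beyond the scatter). The comparison with the 2-fluorophenyl amide points the same way, with 4-ethylphenyl giving a 3.7-fold higher number from compound 1 to compound 3 (0.57 log units; beyond the scatter), so the ethyl compound separates from two neighbours that could not be told apart from each other. Nothing measured here explains why the ethyl group weakens inhibition.

As far as these compounds go, whether a methyl group, a longer propyl chain, an amine or a carboxylic acid at this position would match the chloro compound or weaken inhibition further remains open. From the compounds shown here alone, it is also open whether the loss follows chain length or belongs to ethyl alone.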